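Chain variation at the saturated ring carbon

The compounds below may be only part of what the source reports. "The series", "measured", "known", "first", "only" and "open" are said of these compounds alone.

Values in a functional assay on A549 cells (Homo sapiens) for antiproliferative activity, read by MTT assay, with a stated time of 48 h; on this read-out higher numbers stand for weaker inhibition and lower numbers for stronger inhibition:
Compound 1 `CCCCC1(O)C(=O)Nc2ccc(Nc3ccc(F)cc3)cc21`: 6500 nM
Compound 2 `CC(C)CCC1(O)C(=O)Nc2ccc(Nc3ccc(F)cc3)cc21`: 5700 nM
Compound 3 `CCCCCCC1(O)C(=O)Nc2ccc(Nc3ccc(F)cc3)cc21`: not yet measured

Compound 2 sits level with compound 1, the two values lying within the scatter of each other. The next change is butyl in place of isopropyl on a saturated chain carbon, two bonds along the chain from a saturated ring carbon, butyl in place of isopropyl on a saturated chain carbon. Among the measured compounds shown here, the only measured step on this chain is a 1.1-fold lower number from compound 1 to compound 2 (0.06 log units; within the scatter), which lies within the scatter. It is a single small data point, so no step beyond the scatter is expected in this assay. The expected change is a 1.0-fold lower number from compound 2 to compound 3 (0.02 log units; within the scatter). For compound 3 the estimate is 5500 nM, with an expected range of 2800 nM to 11000 nM.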

Compound 3, half-maximal inhibitory concentration: 12000 nM
Compound 3: middle estimate off by 2.2-fold (0.34 log units), on the low side, outside the stated range (above it).
By their numbers in this assay, from the lowest: compounds 2, 1 and 3 (each within the scatter of the next, the first and the last beyond it).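

In this assay, among the compounds shown here, butyl in place of isopropyl on a saturated chain carbon, two bonds along the chain from a saturated ring carbon, gives a 2.1-fold higher number from compound 2 to compound 3 (0.32 log units; beyond the scatter) and is the first modest step beyond the scatter. Ethyl in place of hydrogen on a saturated chain carbon, four bonds along the chain from a saturated ring carbon, gives a 1.8-fold higher number from compound 1 to compound 3 (0.27 log units; within the scatter) and stays within the scatter, so the hexyl chain separates from the isopentyl chain only. No measured evidence bears on this result. Open, on these data alone, is how a chain longer than hexyl, or an amine or a carboxylic acid in its place, would read.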